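From Methylsulfonyl to Thiazolyl: Cytotoxicity Before the Measurement

The compounds below may be only part of what the source reports. "The series", "measured", "known", "first", "only" and "open" are said of these compounds alone.

Measured so far:
Compound 1 `O=C(Nc1cccc(Cc2ccccc2)c1)C1CCCN(C(=O)c2cccc(-c3ccco3)c2)C1` gives 0% in an ADME assay on PC-3 cells (Homo sapiens) for cytotoxicity, read by WST assay, tested at 100 uM; a lower number here means less inhibition, a higher number more inhibition at the concentration tested (going by the name of the read-out).
Compound 2 `CS(=O)(=O)c1cccc(C(=O)N2CCCC(C(=O)Nc3ccc(Cl)cc3)C2)c1` gives 2% in this assay.

Among the measured compounds shown here, only two compounds have numbers in this assay, and both sit at the bottom of the scale. Compound 2 holds the higher of the two figures, but its gap to compound 1 lies within the scatter of repeated measurements, so the two are best read as the same: neither shows appreciable inhibition at the concentration tested.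

Compound 3 `Cc1nc(-c2cccc(C(=O)N3CCCC(C(=O)Nc4ccc(Cl)cc4)C3)c2)cs1` is the next structure, not yet measured. It differs from compound 2 in one place: 2-methyl-1,3-thiazol-4-yl in place of methylsulfonyl on an aromatic carbon.

For the measured compounds named here, no measured pair in this set shares that kind of change, so nothing here tells how much the number should move. With compound 2 at 2% and compound 1 at 0%, the baseline is flat. The step from compound 2 to compound 3 in this assay is expected to be small, a number 6 percentage points higher from compound 2 to compound 3 (within the scatter), at most a modest rise and most likely within the scatter. Compound 3 is therefore estimated at 8%, with a range from 0% to 30%.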

Compound 3, a percentage reported as inhibition, at one concentration (the size of the read-out at that concentration, not a potency): 1%
Estimate against measurement, compound 3: 7 percentage points above, and the stated range covers the measured number.
By their numbers in this assay, from the lowest: compounds 1, 3 and 2 (each within the scatter of the next).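

In this assay, putting 2-methyl-1,3-thiazol-4-yl in place of methylsulfonyl on an aromatic carbon, meta to a large group, gives a number 1 percentage points lower from compound 2 to compound 3 (within the scatter) and so leaves the reading where it was. Among the compounds shown here, this is the first single change seen, since compound 1 and compound 2 differ in more than one place, and it shows that this position accepts a swap from a group with no ring to one five-membered aromatic ring with 2 hetero atoms, with 6 heavy atoms entering for 4, without any shift that can be told from scatter. Nothing measured here bears on why the reading stays flat.

The compounds shown leave open whether a different kind of group at this place, such as an amine or a carboxylic acid, would move the number off the bottom of the scale in this assay. They also leave open whether the same exchange would read the same way if the 4-chlorophenyl amide of compound 2 were replaced by another amide part.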